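The compounds below may be only part of what the source reports. "The series", "measured", "known", "first", "only" and "open" are said of these compounds alone.

Compound 1 `COc1ccccc1C(=O)NC(=O)Nc1ccc(-c2nccs2)c(C(F)(F)F)c1`: in an ADME assay on LLC-PK1 cells (Sus scrofa) for permeability (on this read-out lower numbers stand for lower permeability and higher numbers for higher permeability), compound 1 gives 12 10^-6 cm/s.
Compound 2 `COc1ccncc1C(=O)NC(=O)Nc1ccc(-c2ccccc2)c(C(F)(F)F)c1`: in this assay compound 2 gives 2.3 10^-6 cm/s.
Compound 3 `COc1ccccc1C(=O)NC(=O)Nc1ccc(N2CCCCC2)c(C(F)(F)F)c1`: in this assay compound 3 gives only a limit, < 1 10^-6 cm/s.

Compound 3 thus stands at the bottom of the shown numbers, at the limit of < 1 10^-6 cm/s in this assay, at which 1 of the 3 values shown sits, so no exact figure is known for it. Compound 4 `COc1ccccc1C(=O)NC(=O)Nc1ccc(-c2ccccc2)c(C(F)(F)F)c1` has not yet been measured in this assay. It differs from compound 3 in one place: phenyl in place of piperidin-1-yl on an aromatic carbon.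

Within the data shown here, only one measured step touches this position. Going from an aromatic ring to piperidin-1-yl gave an at least 12-fold lower number from compound 1 to compound 3 (1.07 log units; beyond the scatter), and the change to compound 4 runs the other way, from piperidin-1-yl back to an aromatic ring. The step to compound 4 is therefore expected to be a large rise in this assay, estimated at an at least 6.0-fold higher number from compound 3 to compound 4 (0.77 log units; beyond the scatter). Compound 2, which also carries a phenyl, gives 2.3 10^-6 cm/s, and compound 1 gives 12 10^-6 cm/s, so compound 4 is estimated to land between them, at 6 10^-6 cm/s, with a range from 2 10^-6 cm/s to 15 10^-6 cm/s.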

Compound 4, apparent permeability in the LLC-PK1 assay: < 1 10^-6 cm/s
Compound 4 gave a limit, no number (the forecaster's own chance of this, stated with the estimate: 10%); at least 6.0-fold (0.77 log units) between middle value and limit.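

Compound 4 ends at a limit, as compound 3 does, so the step between them cannot be read, and in the LLC-PK1 assay the comparison with the thiazole shows an at least 12-fold lower number from compound 1 to compound 4 (1.07 log units; beyond the scatter): at this position, an aromatic ring as such does not bring back the number of compound 1. With 2-methoxyphenyl in place of 4-methoxypyridin-3-yl on a carbonyl carbon, the same assay shows an at least 2.3-fold lower number from compound 2 to compound 4 (0.36 log units; beyond the scatter), so the change at the other end of the molecule also registers on this read-out. In a physicochemical assay for solubility, in simulated intestinal fluid (a lower number here means a less soluble compound, a higher number a more soluble compound), compound 3 gives 4.1 ug/mL and compound 4 gives 23 ug/mL, so the swap of piperidin-1-yl for phenyl, unreadable for permeability, raises the solubility number beyond the usual scatter.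

As far as these compounds go, it remains open how far compound 3 and compound 4 really differ in permeability. Also open, from the compounds shown here alone, is where other groups at this position, such as pyridin-2-yl or morpholin-4-yl, would fall on either read-out.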